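Trimming One Methyl from a Diaryl Ether Agonist

The compounds below may be only part of what the source reports. "The series", "measured", "known", "first", "only" and "open" are said of these compounds alone.

Measured so far:
compound 1, `Cc1ccc(Oc2ccc(CC3SC(=O)NC3=O)cc2)cc1C`: in a functional assay for agonist activity at Free fatty acid receptor 1 (Homo sapiens), read by FLIPR, in the presence of a further agent that is not named here (on this read-out lower numbers stand for an effect already at smaller amounts and higher numbers for an effect only at larger amounts of compound), compound 1 gives 727 nM
compound 2, `Cc1ccc(C)c(Oc2ccc(CC3SC(=O)NC3=O)cc2)c1`: in this assay compound 2 gives 238 nM

Both compounds share one core, a diaryl ether carrying the same acidic ring at one end, and differ only in where two methyl groups sit on the outer ring. Among the compounds with values here, of the two numbers seen so far, compound 2 stands at the lower one; compound 1 is the only neighbour, and its number is higher by a margin beyond the usual scatter, so within this pair compound 2 is the more active.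

The next compound, compound 3 `Cc1ccccc1Oc1ccc(CC2SC(=O)NC2=O)cc1`, is reached from compound 2 by a single change: hydrogen in place of methyl on an aromatic carbon. Within the data shown here, no measured pair in this set shows the same change, so there is no step to read across. Taking away a methyl tends to cost a little activity in series of this kind, but the effect is often small, and an outcome within the scatter would not surprise. For this reason compound 3 is expected to come in slightly weaker than compound 2, with a 1.8-fold higher number from compound 2 to compound 3 (0.25 log units; within the scatter) as the estimated step. Compound 3 is thus estimated at 420 nM, with a range from 150 nM to 1200 nM.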

Compound 3, half-maximal effective concentration: 124 nM
Compound 3: middle estimate off by 3.4-fold (0.53 log units), on the high side, and the stated range ends above it.
By their numbers in this assay, from the lowest: compounds 3 and 2 (each within the scatter of the next); then compound 1.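

In this assay, exchanging the methyl that sits meta to a large group and para to a methyl group for a hydrogen gives a 1.9-fold lower number from compound 2 to compound 3 (0.28 log units; within the scatter), so the two compounds cannot be told apart on this read-out. This shows something the first pair could not: at this position of the outer ring, the methyl can be lost without a change beyond the scatter, and a single methyl on that ring, in the place it holds in compound 3, is enough for activity at this level. No measurement here bears on why this methyl makes so little difference.

The compounds shown leave open whether this position merely accepts hydrogen or methyl, or would also accept something quite different, such as a chlorine atom, a methoxy group or a longer chain like ethyl. They also leave open what happens if the remaining methyl is replaced by hydrogen as well, which would give an outer ring with no methyl at all.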